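The compounds below may be only part of what the source reports. "The series", "measured", "known", "first", "only" and "open" are said of these compounds alone.

Compound 1 `O=c1[nH]c(=O)n([C@H]2C[C@H](O)[C@@H](CO)O2)cc1/C=C/Cl` carries a 2-chloroethenyl group on an aromatic carbon of the shared core. In an ADME assay on L1210/0 cells (Mus musculus) for cytotoxicity, with a stated time of 48 h (a higher number here means a weaker inhibitor, a lower number a stronger inhibitor), compound 1 gives only a limit, > 200000 nM. Compound 2 `CCCC/C=C\c1cn([C@H]2C[C@H](O)[C@@H](CO)O2)c(=O)[nH]c1=O` has hex-1-en-1-yl in place of 2-chloroethenyl on an aromatic carbon. In this assay compound 2 likewise gives only a limit, > 200000 nM. The step that the two limits leave unreadable from compound 1 to compound 2 therefore cannot be read, since (the limit of > 200000 nM in this assay, at which 2 of the 2 values shown sit). Within the data shown here, compound 2 thus stands at the edge of what this assay reports, without a number of its own, and the one further value shown is also a limit. Compound 3 `CC(C)(C)C#Cc1cn([C@H]2C[C@H](O)[C@@H](CO)O2)c(=O)[nH]c1=O` is the next compound to be measured, and it differs from compound 2 as follows: 3,3-dimethylbut-1-yn-1-yl in place of hex-1-en-1-yl on an aromatic carbon. Among the measured compounds shown here, the single measured step concerns the same place on the core, but its size is not readable, so no direction for the new step can be drawn from it. One expects compound 3 to remain beyond the reach of this assay as well, with an estimate of 300000 nM and a range from 100000 nM to 1000000 nM. The expected step that the limit leaves unreadable from compound 2 to compound 3 is accordingly none beyond the scatter.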

Compound 3, half-maximal inhibitory concentration: > 200000 nM
Compound 3 ended at the assay's limit (the forecaster's own chance of this, stated with the estimate: 85%); the middle value does not contradict the limit.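

In this assay compound 3 gives only a limit, > 200000 nM. The steps among compound 1, compound 2 and compound 3 therefore cannot be read: the limit of > 200000 nM in this assay, at which 3 of the 3 values shown sit. The compounds shown leave open how strongly any of them acts on these cells, and whether any group at this place on the shared core would give a measurable value.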